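Series notes: clearance of amine-linked ether analogues

The source may hold more compounds than are shown below. What is called first, only, known or untested is meant among the compounds shown, and "the series" means these compounds.

Compound 1 `c1cc([C@H]2CC[C@]3(CC2)OOC2(O3)C3CC4CC(C3)CC2C4)ccc1OCCCNC1CCOCC1` is the reference point. In an ADME assay on microsomes from liver (Homo sapiens) for metabolic stability, read by LC-MS, tested at 1 uM (a lower number here means slower removal, a higher number faster removal of the compound), compound 1 gives 10 mL.min-1.g-1, the highest of the two numbers in hand; compound 2 `CC(C)(O)CNCCCOc1ccc([C@H]2CC[C@]3(CC2)OOC2(O3)C3CC4CC(C3)CC2C4)cc1` gives 8 mL.min-1.g-1, and the step of a 1.3-fold lower number from compound 1 to compound 2 (0.10 log units; within the scatter) lies within the scatter. Going by the values given here, that single measured step, with a 2-hydroxy-2-methylpropyl in place of oxan-4-yl on an amine nitrogen, is the only comparison available.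

Compound 3 `CC1(C)CC(O)(COc2ccc([C@H]3CC[C@]4(CC3)OOC3(O4)C4CC5CC(C4)CC3C5)cc2)CC(C)(C)N1` differs from compound 1 as follows: 4-hydroxy-2,2,6,6-tetramethylpiperidin-4-yl in place of 2-((oxan-4-yl)amino)ethyl on a saturated chain carbon bound to an oxygen on an aromatic ring. Among the compounds with values here, no measured step covers this change; the step from compound 1 to compound 2 touches only the group on the amine nitrogen, and the rest of the shared core is unchanged throughout. With both measured values close together, the expectation for compound 3 is a step of about no change at the digits printed from compound 1 to compound 3 (within the scatter), that is, nothing beyond the scatter. Compound 3 is therefore estimated at 10 mL.min-1.g-1 in this assay, with a range from 5 mL.min-1.g-1 to 22 mL.min-1.g-1.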

Compound 3, intrinsic clearance in microsomes: 14 mL.min-1.g-1
For compound 3 the middle estimate is 1.4-fold (0.15 log units) below the measured one; low and high end bracket the measured number.
By their numbers in this assay, from the lowest: compounds 2, 1 and 3 (each within the scatter of the next).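

At the saturated chain carbon bound to an oxygen on an aromatic ring, 4-hydroxy-2,2,6,6-tetramethylpiperidin-4-yl in place of 2-((oxan-4-yl)amino)ethyl stays within the scatter in this assay (a 1.4-fold higher number from compound 1 to compound 3 (0.15 log units; within the scatter)), and the same holds when it replaces 2-((2-hydroxy-2-methylpropyl)amino)ethyl (a 1.8-fold higher number from compound 2 to compound 3 (0.24 log units; within the scatter)). The earlier comparison touched only the group on the amine nitrogen; now a change of the whole chain, with the nitrogen inside a six-membered non-aromatic ring, also gives no step beyond the scatter across these three compounds. No measurement at hand accounts for these numbers.

As far as these compounds go, whether a carboxylic acid or a longer chain on the amine nitrogen, or an unsubstituted piperidine at this place, would give a step beyond the scatter remains open. Also open, from the compounds shown here alone, is how this assay would read for a change in the shared core itself.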